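Naphthalen-2-yl Enters the Core of Compound 2

The source may hold more compounds than are shown below. What is called first, only, known or untested is meant among the compounds shown, and "the series" means these compounds.

In an assay on isolated protein for inhibition of protein deacetylase HDAC6 (Homo sapiens), read by fluorescence, with stated times of 10 min and 2 h (a higher number here means a weaker inhibitor, a lower number a stronger inhibitor), compound 1 `O=C(NO)c1ccc(CN2C(=O)CN(Cc3ccc(Cl)cc3)C2=O)cc1` gives 8.3 nM, and compound 2 `CC1(c2ccccc2)NC(=O)N(Cc2ccc(C(=O)NO)cc2)C1=O` gives 74.9 nM, the higher of the two numbers, with compound 1 a good way below it. Compound 3 `O=C(NO)c1ccc(CN2C(=O)NC(Cc3ccc4ccccc4c3)(c3ccccc3)C2=O)cc1` has not yet been measured. It differs from compound 2 by naphthalen-2-yl in place of hydrogen on a saturated chain carbon bound to a saturated ring carbon. For the measured compounds named here, no step between measured compounds is available, so any expectation rests on these two values alone. The step from compound 2 to compound 3 is expected to be a 1.9-fold lower number from compound 2 to compound 3 (0.27 log units; within the scatter), toward a lower number. Compound 3 is expected to give about 40 nM, with a likely range from 12 nM to 130 nM.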

Compound 3, half-maximal inhibitory concentration: 74.6 nM
Estimate against measurement, compound 3: 1.9-fold (0.27 log units) below; low and high end bracket the measured number.
By their numbers in this assay, from the lowest: compound 1; then compounds 3 and 2 (each within the scatter of the next).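

In this assay, for the compounds shown here, the first step at this position reads a 1.0-fold lower number from compound 2 to compound 3 (0.00 log units; within the scatter) and so shows that methyl to (naphthalen-2-yl)methyl, which adds two six-membered aromatic rings of carbon only, leaves the two values indistinguishable. Naphthalen-2-yl is therefore accommodated on this saturated chain carbon without any measurable change in the number. No evidence here bears on why the values coincide. Going by these compounds, whether an amine, a carboxylic acid or a longer chain ending in naphthalen-2-yl at this place would read the same remains open.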